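This account rests on a few compounds, and the source may have more. Where it says the series, first, only, none or still open, it means among the compounds named here.

Measured compounds:
- compound 1, `CCc1cccc(NC(=O)N[C@@H](C)c2ccccc2)c1`, 86% in an ADME assay on the whole organism with Oryza sativa as the target, tested at 10 uM; a higher number here means a weaker effect of the compound at the concentration tested, a lower number a stronger effect
- compound 2, `CCOC(=O)c1cccc(NC(=O)N[C@@H](C)c2ccccc2)c1`, 96%

Among the compounds with values here, compound 2 holds the highest of the two numbers measured so far in this assay; the nearest is compound 1, and the step of a number 10 percentage points higher from compound 1 to compound 2 (within the scatter) lies within the scatter, so the two cannot be ordered against each other. Compound 3, `COc1cccc(NC(=O)N[C@@H](C)c2ccccc2)c1`, has not yet been tested. It differs from compound 2 in one place: methoxy in place of ethoxycarbonyl on an aromatic carbon. Within the data shown here, the only measured step that bears on this change is the one at the same aromatic carbon, a number 10 percentage points higher from compound 1 to compound 2 (within the scatter), which swapped one group for another there without moving the number beyond the scatter. On that basis the swap to methoxy is expected to leave the number where compound 2 stands, with no step beyond the scatter, and the expected change is a number 5 percentage points lower from compound 2 to compound 3 (within the scatter). For compound 3 the estimate in this assay is 91%, with a likely range from 76% to 100%.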

Compound 3, a percentage reported as activity, at one concentration (the size of the read-out at that concentration, not a potency): 99%
Estimate against measurement, compound 3: 8 percentage points below, within the range that was stated.
By their numbers in this assay, from the lowest: compounds 1, 2 and 3 (each within the scatter of the next, the first and the last beyond it).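

At this aromatic carbon in this assay, the exchange of ethoxycarbonyl, with 5 heavy atoms and 2 hydrogen-bond acceptors, for methoxy, with 2 heavy atoms and 1 hydrogen-bond acceptor, gives a step that cannot be told apart from repeat measurements (a number 3 percentage points higher from compound 2 to compound 3 (within the scatter)). This shows that removing much of the larger group does not by itself separate the two compounds in this read-out. Within the data shown here, the comparison with ethyl gives the first step beyond the scatter, though only a modest one (a number 13 percentage points higher from compound 1 to compound 3 (beyond the scatter)), so the group on this carbon can shift the number, with methoxy giving the weaker effect at the concentration tested; nothing available here accounts for this shift.

Compound 2 lies within the scatter of both other compounds. This rests on one pair and does not establish a trend across the three groups. From the compounds shown here alone, it remains open how an amine, a carboxylic acid or a longer chain on this carbon would read, and whether changes elsewhere on the shared core would move the number further.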